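Swapping fluoro for hydrogen in compound 2

The source may report more compounds than this note shows. Statements on the series, on what has been measured and on what is new or still open speak of the compounds shown alone.

Measured in a functional assay on PC-3 cells (Homo sapiens) for antiproliferative activity, read by MTT assay, with a stated time of 72 h; on this read-out lower numbers stand for stronger inhibition and higher numbers for weaker inhibition:
Compound 1 `O=C(N/N=C/c1ccc(F)cc1)Nc1ccc(Oc2ccnc3[nH]ccc23)c(F)c1`: 2330 nM
Compound 2 `COc1ccc(/C=N/NC(=O)Nc2ccc(Oc3ccnc4[nH]ccc34)c(F)c2)c(OC)c1OC`: 8970 nM
Compound 3 `COc1ccc(/C=N/NC(=O)Nc2ccc(Oc3ccnc4[nH]ccc34)cc2)cc1`: "not active" (no number reported)

Of the two numbers available, compound 2 has the higher, so it is the weaker inhibitor of that pair, and the gap to compound 1 lies beyond the usual scatter. Compound 4 `COc1ccc(/C=N/NC(=O)Nc2ccc(Oc3ccnc4[nH]ccc34)cc2)c(OC)c1OC` is compound 2 with hydrogen in place of fluoro on an aromatic carbon. Among the measured compounds shown here, no measured pair shows this change alone. Compound 3, which also has no fluoro but differs elsewhere too, is reported as "not active" (no number reported), without a number. A small shift towards weaker inhibition in this assay is therefore expected, perhaps none beyond the scatter. The expected step is a 1.3-fold higher number from compound 2 to compound 4 (0.13 log units; within the scatter). For compound 4 the estimated value is 12000 nM, with an expected range of 5000 nM to 30000 nM.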

Compound 4, half-maximal inhibitory concentration: 27600 nM
The estimate for compound 4 lay 2.3-fold (0.36 log units) below the measured number; measured number inside the range.
By their numbers in this assay, from the lowest: compound 1; then compound 2; then compound 4.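

This is the only pair shown that isolates fluoro on this aromatic carbon, ortho to a large group and meta to a large group. In this assay, hydrogen in place of fluoro gives a 3.1-fold higher number from compound 2 to compound 4 (0.49 log units; beyond the scatter), so the two are not interchangeable here, which compound 3 could not show because it also differs elsewhere. Nothing available explains this shift. As far as these compounds go, whether the same swap would move compound 1 by a similar amount remains open. So does how a chloro group or an amine at this place would compare.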